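Swapping tert-butyl for chloro on a weak thiazolidinedione

The source may hold more compounds than are shown below. What is called first, only, known or untested is meant among the compounds shown, and "the series" means these compounds.

Measured compounds:
Compound 1 `C=C(Br)C(=O)Nc1cccc(/C=C2\SC(=O)N(Cc3ccc(Cl)cc3)C2=O)c1`: 1400 nM
Compound 2 `CC(C)(C)c1ccc(CN2C(=O)S/C(=C\c3ccc(N)cc3)C2=O)cc1`: 66000 nM
Compound 3 `C=C(Br)C(=O)Nc1ccc(/C=C2\SC(=O)N(Cc3cccc(F)c3)C2=O)cc1`: 3200 nM

In a functional assay on CCRF-CEM cells (Homo sapiens) for cytotoxicity, read by cell counting, with a stated time of 3 days (on this read-out higher numbers stand for weaker inhibition and lower numbers for stronger inhibition), compound 2 gives the highest number of the three. Compound 3, the nearest to it, differs from compound 2 in more than one place, so their values can only be set side by side; the same holds for compound 1, which sits furthest from compound 2. Both compound 1 and compound 3 carry a bromoacrylamide where compound 2 carries an amino group, and nothing in the set isolates that difference from the others.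

Compound 4 `Nc1ccc(/C=C2\SC(=O)N(Cc3ccc(Cl)cc3)C2=O)cc1` has not yet been tested in this assay. It differs from compound 2 in a single place: chloro in place of tert-butyl on an aromatic carbon. Among the measured compounds shown here, because compound 2 gives 66000 nM and no step of this kind has been measured here, a step of this size is expected to be modest, in either direction or none beyond the scatter, a 1.3-fold lower number from compound 2 to compound 4 (0.12 log units; within the scatter). Compound 4 is expected to give about 50000 nM, with a range from 15000 nM to 150000 nM.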

Compound 4, half-maximal inhibitory concentration: 87000 nM
Compound 4: the middle estimate sits 1.7-fold (0.24 log units) below what was measured, within the range that was stated.
By their numbers in this assay, from the lowest: compound 1; then compound 3; then compounds 2 and 4 (each within the scatter of the next).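

In this assay, among the compounds shown here, chloro in place of tert-butyl on an aromatic carbon gives a 1.3-fold higher number from compound 2 to compound 4 (0.12 log units; within the scatter), the first step in this set that changes only one place. At this position, para to a large group, four carbon atoms give way to a single chlorine without a shift beyond the scatter, so the two groups cannot be told apart by this read-out while the amino group and the rest of the structure stay fixed. No supporting data bear on why the step is so small.

As far as these compounds go, it remains open whether a different group at this position, such as a methoxy group or a carboxylic acid, would move the number beyond the scatter. From the compounds shown here alone, it also remains open whether the same exchange would give a similar step in a compound carrying the bromoacrylamide in place of the amino group.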